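The source may report more compounds than this note shows. Statements on the series, on what has been measured and on what is new or still open speak of the compounds shown alone.

Compound 1 (`COc1cccc(CNC(=O)N2C(=O)c3ccccc3S2(=O)=O)c1`) in a physicochemical assay for pharmacokinetics (a lower number here means that the compound disappears faster, a higher number that the compound lasts longer), gives a limit (> 166 h)
Compound 2 (`O=C(NCc1ccc(C(F)(F)F)cc1)N1C(=O)c2ccccc2S1(=O)=O`) gives a limit (> 166 h)
Compound 3 (`O=C(OCc1ccccc1)N1C(=O)c2ccccc2S1(=O)=O`) gives a limit (> 166 h)

Compound 1 has no exact number in this assay, only a limit, and it shares this position with the other two compounds (the limit of > 166 h in this assay, at which 3 of the 3 values shown sit). Compound 4 (`O=C(NCC1CCCCC1)N1C(=O)c2ccccc2S1(=O)=O`) has cyclohexyl in place of 3-methoxyphenyl on a saturated chain carbon bound to an amide-type nitrogen. Within the data shown here, no measured pair differing in one place is available to size this step. With compound 1 known only as a limit (> 166 h), no change beyond the scatter is expected. The estimated step (a step that the limit leaves unreadable from compound 1 to compound 4) is therefore expected to be small. Compound 4 is estimated at 200 h, with an expected range from 100 h to 400 h.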

Compound 4, half-life: > 166 h
Compound 4: a limit, no number; the forecaster's own chance of this, stated with the estimate: 80%; the middle value does not contradict the limit.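

Compound 4, like compound 1, gives only a limit in this assay, so no step can be read between them: the limit of > 166 h in this assay, at which 4 of the 4 values shown sit. The compounds shown leave open how long any of them actually lasts, and whether cyclohexyl and 3-methoxyphenyl differ at all.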